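Bromophenyl Analogue After a Hydroxyphenyl at the Limit

This account rests on a few compounds, and the source may have more. Where it says the series, first, only, none or still open, it means among the compounds named here.

Compound 3 `Cn1nc(-c2nnc(-c3ccc(O)cc3)o2)c2ccccc21` carries a 4-hydroxyphenyl group on the shared core. In an ADME assay on L02 cells (Homo sapiens) for cytotoxicity, read by MTT assay, with a stated time of 72 h (on this read-out lower numbers stand for stronger inhibition and higher numbers for weaker inhibition), compound 3 reaches only the limit of the assay, > 100000 nM. Compound 1 `Cn1nc(-c2nnc(-c3ccccc3)o2)c2ccccc21`, which carries a plain phenyl group, gives a measurable number in this assay, 84600 nM. Compound 2 `Cn1nc(-c2nnc(-c3cccc(Cl)c3)o2)c2ccccc21`, which carries a 3-chlorophenyl group, sits at the limit of this assay, > 100000 nM. The step of an at least 1.1-fold higher number from compound 1 to compound 2 (0.07 log units; that floor lies within the scatter) and the step of an at least 1.1-fold higher number from compound 1 to compound 3 (0.07 log units; that floor lies within the scatter) are both floors that stay inside the scatter, and the step that the two limits leave unreadable from compound 2 to compound 3 cannot be read at all. What the measured series mainly shows is the limit of > 100000 nM in this assay, at which 2 of the 3 values shown sit.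

Compound 4 `Cn1nc(-c2nnc(-c3ccccc3Br)o2)c2ccccc21` has not yet been measured in this assay. It differs from compound 3 by 2-bromophenyl in place of 4-hydroxyphenyl on an aromatic carbon. For the measured compounds named here, no measured step moved beyond the scatter, and two of the three values stop at the limit, so there is no basis for expecting a marked move in either direction. The step is expected to be a step that the limit leaves unreadable from compound 3 to compound 4. Compound 4 is therefore estimated at 120000 nM, with a range from 50000 nM to 300000 nM, and with a real chance that this assay again reports only a limit for it.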

Compound 4, half-maximal inhibitory concentration: 89000 nM
Compound 4: the middle estimate sits 1.3-fold (0.13 log units) above what was measured; measured number inside the range.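

In this assay, for the compounds shown here, bromo in place of hydrogen gives the first comparison between two readable numbers, and it shows no move that can be told from the scatter: a 1.1-fold higher number from compound 1 to compound 4 (0.02 log units; within the scatter). The other two steps are only floors that stay within the scatter, an at least 1.1-fold lower number from compound 3 to compound 4 (0.05 log units; that floor lies within the scatter) and an at least 1.1-fold lower number from compound 2 to compound 4 (0.05 log units; that floor lies within the scatter), so neither 2-bromophenyl in place of 4-hydroxyphenyl nor 2-bromophenyl in place of 3-chlorophenyl is shown to shift the number on this aromatic carbon. The groups at this position therefore still cannot be ranked, because part of the series stops at a limit: the limit of > 100000 nM in this assay, at which 2 of the 4 values shown sit.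

The compounds shown leave open whether any group at this position would give a number clearly lower than those of compound 1 and compound 4, for instance a phenyl group carrying an amine or a carboxylic acid. They also leave open whether a 4-bromophenyl or a 3-bromophenyl group would read as the 2-bromophenyl group of compound 4 does, or would instead stop at the limit.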